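Ring size on the urea carbonyl in a chemokine receptor series

A few compounds are considered here, and "the series" means these few. Any claim that something is new, unique, unknown or untested is made for them only; others in the source may bear on it.

Measured compounds:
compound 1, `Cc1ccccc1C(=O)Nc1ccc(S(=O)(=O)NC2CCN(C(N)=O)CC2)c2ccccc12`, with 243 nM
compound 2, `Cc1ccccc1C(=O)Nc1ccc(S(=O)(=O)NC2CCN(C(=O)N3CCC3)CC2)c2ccccc12`, with 3.5 nM

Within the data shown here, in an assay on L1.2 cells for binding affinity to C-C chemokine receptor type 8 (Homo sapiens) (a higher number here means a weaker inhibitor, a lower number a stronger inhibitor), compound 2 gives 3.5 nM, the lowest of the two numbers so far; its nearest neighbour is compound 1, separated by a 69-fold lower number from compound 1 to compound 2 (1.84 log units; beyond the scatter). Among the measured compounds shown here, that step, azetidin-1-yl in place of amino on the carbonyl carbon, is the only measured step in the set, and it is large.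

Compound 3, `Cc1ccccc1C(=O)Nc1ccc(S(=O)(=O)NC2CCN(C(=O)N3CCCCC3)CC2)c2ccccc12`, takes the same place one size further: piperidin-1-yl in place of azetidin-1-yl on a carbonyl carbon. For the measured compounds named here, the one measured step bears on it only loosely: it shows that closing the amino into a ring on this carbonyl lowered the number greatly, but it says nothing about how a larger ring compares with a smaller one, since both rings are untested against each other. Going by the values given here, with no direct precedent, a step of modest size is expected in this assay, in either direction, and most likely within the scatter.

For compound 3 a value of 5 nM is expected, in the range 1.5 nM to 20 nM. This estimate means a step of a 1.4-fold higher number from compound 2 to compound 3 (0.15 log units; within the scatter).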

Compound 3, inhibition constant: 4.2 nM
Compound 3: the middle estimate sits 1.2-fold (0.08 log units) above what was measured, within the range that was stated.
By their numbers in this assay, from the lowest: compounds 2 and 3 (each within the scatter of the next); then compound 1.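

In this assay, enlarging the ring from azetidin-1-yl to piperidin-1-yl on this carbonyl carbon gives a 1.2-fold higher number from compound 2 to compound 3 (0.08 log units; within the scatter), so the two ring sizes tested cannot be told apart here, even though the piperidin-1-yl group has 6 heavy atoms against 4 for azetidin-1-yl. The large step away from amino is therefore not confined to the four-membered ring: piperidin-1-yl in place of amino gives a 58-fold lower number from compound 1 to compound 3 (1.76 log units; beyond the scatter), a step of similar size to a 69-fold lower number from compound 1 to compound 2 (1.84 log units; beyond the scatter) seen with azetidin-1-yl. No supporting evidence is available to explain either the large step from amino or the lack of separation between the two rings.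

The compounds shown leave open whether a pyrrolidin-1-yl or morpholin-4-yl ring on the same carbonyl would match compound 2 and compound 3, and whether a larger azepan-1-yl ring would do so as well. They also leave open whether an open-chain dimethylamino or diethylamino group would read like the rings or like the amino group of compound 1.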